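Swapping the Ring-Nitrogen Substituent on an Aminothiophene Core

The compounds below may be only part of what the source reports. "The series", "measured", "known", "first", "only" and "open" are said of these compounds alone.

Measured so far:
compound 1 `CC(C)N1CCN(Cc2csc(N)c2C(=O)c2ccc(Cl)cc2)CC1` — 0%
compound 2 `Nc1scc(CN2CCN(c3cccnc3)CC2)c1C(=O)c1ccc(Cl)cc1` — 0%
compound 3 `Nc1scc(CN2CCN(C3CCCCCC3)CC2)c1C(=O)c1ccc(Cl)cc1` — 0%

In an assay on CHO cells for displacement of a labelled ligand from adenosine receptor A3 (Homo sapiens), read by scintillation counting, with a stated time of 120 min, tested at 10 uM (on this read-out lower numbers stand for less inhibition and higher numbers for more inhibition at the one concentration tested (going by the name of the read-out)), compound 1 gives 0%, level with compounds 2 and 3. The step of no change at the digits printed from compound 1 to compound 2 (within the scatter) and the step of no change at the digits printed from compound 1 to compound 3 (within the scatter) both lie within the scatter, so three different groups on the ring nitrogen leave the read-out unchanged.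

Compound 4 `Nc1scc(CN2CCN(c3ccc(F)cc3F)CC2)c1C(=O)c1ccc(Cl)cc1` is the next variation on the shared core: 2,4-difluorophenyl in place of isopropyl on an amine nitrogen in a ring. Both earlier steps at this same position bear on it, and neither moved the read-out. An aromatic group at this position, as in compound 2, also gave 0%. The expectation is therefore a step of a number 2 percentage points higher from compound 1 to compound 4 (within the scatter) of no size beyond the scatter. For compound 4 the estimated value is 2%, with a range from -8% to 15%.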

Compound 4, a percentage reported as inhibition, at one concentration (the size of the read-out at that concentration, not a potency): 0%
Compound 4: middle estimate off by 2 percentage points, on the high side; the measured number falls inside the stated range.
By their numbers in this assay, from the lowest: compounds 1, 2, 3 and 4 (each within the scatter of the next).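

With 2,4-difluorophenyl on the ring nitrogen, an aromatic ring of carbon only, bearing fluorine, joins the groups tested at this position. In this assay the steps of no change at the digits printed from compound 1 to compound 4 (within the scatter) and no change at the digits printed from compound 3 to compound 4 (within the scatter) and no change at the digits printed from compound 2 to compound 4 (within the scatter) show that it reads the same as isopropyl, cycloheptyl and pyridin-3-yl. Nothing available here explains this flat result. The compounds shown leave open whether a carboxylic acid or an amine on a longer chain at this ring nitrogen would lift the read-out, and whether a change elsewhere on the shared core would.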